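The source may report more compounds than this note shows. Statements on the series, on what has been measured and on what is new or still open speak of the compounds shown alone.

Measured compounds:
- compound 1, `CC(C)=CCOc1ccc(C(=O)/C=C/c2ccc(C)cc2)c(O)c1`: 1030 nM
- compound 2, `COc1ccc(C(=O)/C=C/c2ccc(Cl)cc2)cc1`: 54 nM

In an assay on isolated protein for inhibition of Amine oxidase [flavin-containing] B (Homo sapiens) (on this read-out higher numbers stand for weaker inhibition and lower numbers for stronger inhibition), compound 2 gives the lower of the two numbers; compound 1 stands well beyond the scatter on the higher side of it. Going by the values given here, the two structures differ in more than one place, so no single step can be drawn between them, and nothing beyond these two values is known for the series in this assay.

Compound 3, `COc1ccc(C(=O)/C=C/c2ccc(OCc3ccccc3)cc2)cc1`, is the next point. It differs from compound 2 in one place: benzyloxy in place of chloro on an aromatic carbon. The group that enters is much larger and brings one hydrogen-bond acceptor where the chloro group had none. Among the compounds with values here, no measured pair shows what such an exchange does to this read-out here, so the direction of the step rests on the structural change alone.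

The expectation is that compound 3 stays near compound 2, with a step of a 1.5-fold higher number from compound 2 to compound 3 (0.17 log units; within the scatter) that would not clearly exceed the scatter. Compound 3 is estimated at 80 nM, with a range from 15 nM to 400 nM.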

Compound 3, half-maximal inhibitory concentration: 450 nM
Compound 3: middle estimate off by 5.6-fold (0.75 log units), on the low side; measured number above the stated range.
By their numbers in this assay, from the lowest: compound 2; then compound 3; then compound 1.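

In this assay, going by these compounds alone, the exchange of chloro for benzyloxy on an aromatic carbon, para to a large group, gives an 8.3-fold higher number from compound 2 to compound 3 (0.92 log units; beyond the scatter) and provides the first single-place step. This position is therefore not indifferent to its substituent: replacing a single chlorine with a group of 8 heavy atoms, carrying a six-membered aromatic ring and one hydrogen-bond acceptor, moves the read-out toward weaker inhibition. Nothing measured in the series explains this step.

The exchange alters atom count, ring content and acceptor count at once, so compounds 2 and 3 cannot show which of these changes tracks the higher number. A phenyl group would keep the ring without the ether oxygen, and an ethoxy group would keep the oxygen without the ring, while a fluoro group or a primary amine at the same carbon would show whether other small groups stay close to chloro.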